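The source may report more compounds than this note shows. Statements on the series, on what has been measured and on what is new or still open speak of the compounds shown alone.

Notes on the shared core, all compounds read in an assay on HEK293 cells for negative allosteric modulation of metabotropic glutamate receptor 5 (Homo sapiens), read by FLIPR; on this read-out lower numbers stand for stronger inhibition and higher numbers for weaker inhibition. Compound 1 `O=C(c1ccc(Cl)cc1)N1CC(c2nc(-c3cccc(F)c3)no2)C1` gives > 10000 nM in this assay, which is a limit of the assay rather than a number. Compound 2 `CC1CCCCC1C(=O)N1CC(c2nc(-c3cccc(F)c3)no2)C1` gives > 10000 nM in this assay, again only a limit. The change from compound 1 to compound 2, 2-methylcyclohexyl in place of 4-chlorophenyl on a carbonyl carbon, therefore amounts to a step that the two limits leave unreadable from compound 1 to compound 2. Compound 3 `O=C(N1CCCCC1)N1CC(c2nc(-c3cccc(Cl)c3)no2)C1` gives > 10000 nM in this assay, a limit of the assay and not a number. Compound 3 thus stands with the other two, all three values sitting at the limit of > 10000 nM in this assay, at which 3 of the 3 values shown sit.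

Compound 4 `CC1CCN(C(=O)N2CC(c3nc(-c4cccc(Cl)c4)no3)C2)CC1` differs from compound 3 by methyl in place of hydrogen on a saturated ring carbon. Among the compounds with values here, the only measured step, from compound 1 to compound 2, bears on this change just in showing that the series so far has produced no readable number; there is no measured step of methyl for hydrogen on a saturated ring carbon to draw on, and no direction can be read from the data in hand. The expected outcome for compound 4 is that this assay reports a limit once more, an expected step that the limit leaves unreadable from compound 3 to compound 4. Compound 4 is estimated at 20000 nM, with a range from 8000 nM to 60000 nM.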

Compound 4, half-maximal inhibitory concentration: > 10000 nM
Compound 4 gave a limit, no number; the forecaster's own chance of this, stated with the estimate: 80%; the middle value is on the limit's open side.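

In this assay compound 4 gives > 10000 nM, a limit of the assay and not a number. Compound 3 also sits at a limit, so no step can be read between compound 3 and compound 4. The compounds shown leave open whether any change on the shared core yields a readable number, the series standing thus: the limit of > 10000 nM in this assay, at which 4 of the 4 values shown sit.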